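Trimming the triazole substituent of a weak antiproliferative lactone

The source may report more compounds than this note shows. Statements on the series, on what has been measured and on what is new or still open speak of the compounds shown alone.

Measured compounds:
Compound 1, `COc1ccc(-c2cn(C/C=C3\OC(=O)C(OCc4ccccc4)=C3OCc3ccccc3)nn2)cc1`: > 100000 nM
Compound 2, `COc1ccc(-c2cn(C[C@H](O)[C@H]3OC(=O)C(OCc4ccccc4)=C3OCc3ccccc3)nn2)cc1`: 58200 nM

The two measured compounds share a lactone core carrying two benzyloxy groups and a triazole bearing a 4-methoxyphenyl group. In a functional assay on SW-620 cells (Homo sapiens) for antiproliferative activity, read by MTT assay, with a stated time of 72 h (on this read-out lower numbers stand for stronger inhibition and higher numbers for weaker inhibition), compound 1 reaches only the limit > 100000 nM, which is a limit of the assay rather than a number. In this assay, among the measured compounds shown here, compound 2 gives 58200 nM, the only number among the two values shown. The value of compound 1 sits at the limit described by the limit of > 100000 nM in this assay, at which 1 of the 2 values shown sits.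

Compound 3, `O=C1O[C@H]([C@@H](O)Cn2ccnn2)C(OCc2ccccc2)=C1OCc1ccccc1`, has not yet been measured. It differs from compound 2 by hydrogen in place of 4-methoxyphenyl on an aromatic carbon. For the measured compounds named here, the data hold no measured step for such a removal of a 4-methoxyphenyl group, so the direction can only be guessed from the weak activity of compound 2 at 58200 nM. The step from compound 2 to compound 3 is expected to move toward weaker inhibition, possibly beyond the scatter, as a 1.7-fold higher number from compound 2 to compound 3 (0.24 log units; within the scatter). Compound 3 is therefore estimated at 100000 nM, within a range from 40000 nM to 300000 nM.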

Compound 3, half-maximal inhibitory concentration: > 100000 nM
Compound 3 gave a limit, no number (the forecaster's own chance of this, stated with the estimate: 55%); the middle value sits exactly at the limit.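

Replacing the 4-methoxyphenyl group on the aromatic carbon of the triazole with hydrogen gives an at least 1.7-fold higher number from compound 2 to compound 3 (0.23 log units; that floor lies within the scatter) in this assay. Compound 3 returns a limit of the assay and not a number, so this step is only a floor: the true change could be small or much larger, and the data do not show that the 4-methoxyphenyl group is needed for the weak activity of compound 2. Compound 3 now stands with compound 1 at the same limit: the limit of > 100000 nM in this assay, at which 2 of the 3 values shown sit.

As far as these compounds go, what remains open is whether any activity at this position depends on the 4-methoxyphenyl group in particular, or whether another group on the triazole would serve as well or better. A plain phenyl ring, a 4-hydroxyphenyl group or an aminomethyl group on that aromatic carbon would help to separate these possibilities, ideally with values that fall inside the measurable range of the assay rather than at its limit.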